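The compounds below may be only part of what the source reports. "The series", "measured", "known", "first", "only" and "open" are said of these compounds alone.

Measured so far in a functional assay on SW620/5-FU cells (Homo sapiens) for cytotoxicity, read by MTT assay, with a stated time of 48 h, in the presence of a further agent that is not named here; a higher number here means that more compound is needed for the effect, a lower number that less compound is needed:

compound 1 `COc1ccc(-c2cc(NNC(=O)Nc3cc(Cl)nc(Cl)c3)nc3c2cnn3C)cc1`: 18500 nM
compound 2 `COc1ccc(-c2cc(NNC(=O)Nc3cc(Cl)nc(OC)c3)nc3c2cnn3C)cc1`: 48800 nM
compound 3 `COc1cc(NC(=O)NNc2cc(-c3ccc(F)cc3)c3cnn(C)c3n2)cc(Cl)n1`: 24100 nM

Two single changes connect the measured set. From compound 2 to compound 1 the change is chloro in place of methoxy on an aromatic carbon, and in this assay it gives a 2.6-fold lower number from compound 2 to compound 1 (0.42 log units; beyond the scatter). Compound 1 and compound 3 have not been compared as a step; their two numbers lie within the usual scatter of each other, so no order between them is claimed.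

Compound 4 `Cn1ncc2c(-c3ccc(F)cc3)cc(NNC(=O)Nc3cc(Cl)nc(Cl)c3)nc21` has not yet been measured in this assay. It differs from compound 3 by chloro in place of methoxy on an aromatic carbon. For the measured compounds named here, this is the same change as the one from compound 2 to compound 1, and the place at which it occurs reads the same word for word in both pairs. The two cores differ by fluoro in place of methoxy on an aromatic carbon, a change that on its own gave a 2.0-fold lower number from compound 2 to compound 3 (0.31 log units; beyond the scatter) in this assay. Going by the values given here, the only precedent for the change to compound 4 is therefore the step from compound 2 to compound 1, made on the other core.

Among the compounds with values here, on that basis the step from compound 3 to compound 4 is expected to be a 2.5-fold lower number from compound 3 to compound 4 (0.40 log units; beyond the scatter), set beside a 2.6-fold lower number from compound 2 to compound 1 (0.42 log units; beyond the scatter) as the one measured instance. The estimate for compound 4 in this assay is 9500 nM, with an expected range from 4500 nM to 20000 nM, resting on a single prior step and so held loosely.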

Compound 4, half-maximal effective concentration: 9150 nM
Compound 4: middle estimate off by 1.0-fold (0.02 log units), on the high side; low and high end bracket the measured number.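

In this assay, chloro in place of methoxy on the 2-chloro-6-methoxypyridin-4-yl group gives a 2.6-fold lower number from compound 3 to compound 4 (0.42 log units; beyond the scatter), and this change carries from the core of compound 2 to the core of compound 3 without a gap beyond the scatter: the same change on two cores in this assay, a 2.6-fold lower number (0.42 log units; beyond the scatter) from compound 2 to compound 1 and a 2.6-fold lower number (0.42 log units; beyond the scatter) from compound 3 to compound 4, 1.0-fold (0.00 log units) apart, within the scatter of two such steps

Read the other way, fluoro in place of methoxy on the aryl group gives a 2.0-fold lower number from compound 1 to compound 4 (0.31 log units; beyond the scatter), which also matches its earlier instance: the same change on two cores in this assay, a 2.0-fold lower number (0.31 log units; beyond the scatter) from compound 2 to compound 3 and a 2.0-fold lower number (0.31 log units; beyond the scatter) from compound 1 to compound 4, 1.0-fold (0.00 log units) apart, within the scatter of two such steps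

These two agreements come from the same four compounds and so count as one observation of additive steps, not two; they show that the two changes combine in this set in this assay, but they do not show why, nor that the chloro step would hold on any core beyond these two.

Only chloro and methoxy are shown at the varied place on the pyridinyl group, so it remains open whether an amine or a longer alkoxy chain there would follow the same additive pattern. On the aryl group only fluoro and methoxy are shown, which leaves open how a nitrile or a carboxylic acid at that place would combine with the chloro step.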